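This account rests on a few compounds, and the source may have more. Where it says the series, first, only, none or still open, it means among the compounds named here.

Compound 3 `O[C@H](COCCOC[C@@H](O)Cc1c[nH]nn1)Cc1ccc(-c2ccccc2)cc1` carries no group on the aromatic nitrogen of its triazole. In a functional assay on SGC-7901 cells (Homo sapiens) for inhibition, read by MTT assay, with a stated time of 72 h (a higher number here means a weaker inhibitor of growth, a lower number a stronger inhibitor of growth), compound 3 gives only a limit, > 100000 nM. Compound 2 `O[C@H](COCCOC[C@@H](O)Cc1cn(-c2cncnc2)nn1)Cc1ccc(-c2ccccc2)cc1` carries pyrimidin-5-yl on that nitrogen, and in this assay compound 2 also gives only a limit, > 100000 nM. Compound 1 `O=C1COc2ccc(-n3cc(C[C@H](O)COCCOC[C@@H](O)Cc4ccc(-c5ccccc5)cc4)nn3)cc2N1` carries the largest group of the three on the same nitrogen; in this assay compound 1 gives 15200 nM. Two of the three values thus sit at the limit of > 100000 nM in this assay, at which 2 of the 3 values shown sit. The steps of an at least 6.5-fold higher number from compound 1 to compound 3 (0.81 log units; beyond the scatter) and an at least 6.5-fold higher number from compound 1 to compound 2 (0.81 log units; beyond the scatter) both show the number rising when the large group on the aromatic nitrogen is removed or replaced by a small one, while the step that the two limits leave unreadable from compound 2 to compound 3 cannot be read. Compound 4 `O=c1[nH]c2ccc(-n3cc(C[C@H](O)COCCOC[C@@H](O)Cc4ccc(-c5ccccc5)cc4)nn3)cc2s1` arises from compound 3 by a group of 10 heavy atoms (7 carbon, 1 nitrogen, 1 oxygen, 1 sulfur; one five-membered aromatic ring with 2 hetero atoms, one six-membered aromatic ring of carbon only) in place of a hydrogen atom, on an aromatic nitrogen. This reinstates a large group of the kind compound 1 carries, so the expected step is a drop in the number, an at least 6.6-fold lower number from compound 3 to compound 4 (0.82 log units; beyond the scatter), back toward the value of compound 1. Compound 4 is estimated at 15000 nM, with a range from 5000 nM to 60000 nM.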

Compound 4, concentration for 50% growth inhibition: 10500 nM
The estimate for compound 4 lay 1.4-fold (0.15 log units) above the measured number; measured number inside the range.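

In this assay, a second large group on the aromatic nitrogen, this one with sulfur in its five-membered aromatic ring, again gives a measurable number: an at least 9.5-fold lower number from compound 3 to compound 4 (0.97 log units; beyond the scatter), and an at least 9.5-fold lower number from compound 2 to compound 4 (0.97 log units; beyond the scatter). The two large groups are not told apart, a 1.4-fold lower number from compound 1 to compound 4 (0.16 log units; within the scatter), so at this position a five-membered aromatic ring with 2 hetero atoms and a six-membered non-aromatic ring with 2 hetero atoms serve alike in the two compounds shown. The first two steps start from limits, so their true size stays unread: the limit of > 100000 nM in this assay, at which 2 of the 4 values shown sit.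

Open, on these data alone, is whether phenyl alone on that nitrogen would give a measurable number, or whether the second ring is needed. Also open, as far as these compounds go, is whether naphthyl, which has neither the carbonyl nor the ring hydrogen, would hold the value of compound 4.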